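This account rests on a few compounds, and the source may have more. Where it says the series, first, only, none or still open, it means among the compounds named here.

For the measured compounds named here, in a functional assay on RPMI-8226 cells (Homo sapiens) for cytotoxicity, read by MTT assay, with a stated time of 48 h (a higher number here means a weaker inhibitor, a lower number a stronger inhibitor), two compounds have numbers so far. Compound 1 (`O=C(c1ccccc1)N(N=C1C(Cl)=C(Cl)C(Cl)=C1Cl)C(=O)c1ccccc1`) gives 800 nM, and compound 2 (`FC(F)(F)c1cccc(NN=C2C(Cl)=C(Cl)C(Cl)=C2Cl)c1`) gives 110 nM, the lower of the two numbers, with a gap between them that lies beyond the usual scatter. The next compound, compound 3 (`Cc1cccc(NN=C2C(Cl)=C(Cl)C(Cl)=C2Cl)c1`), keeps the rest of compound 2 but carries methyl in place of trifluoromethyl on an aromatic carbon. Going by the values given here, no measured pair shows this swap on its own, so its size can only be judged loosely. A modest rise in the number is expected, perhaps a little beyond the scatter, though a step within the scatter would be no surprise. The estimated step is a 1.8-fold higher number from compound 2 to compound 3 (0.26 log units; within the scatter). For compound 3 the expected value is 200 nM, with an estimated range of 60 nM to 600 nM.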

Compound 3, half-maximal inhibitory concentration: 2000 nM
Beside the measured number, compound 3's estimate is 10-fold (1.00 log units) below it; measured number above the stated range.
By their numbers in this assay, from the lowest: compound 2; then compound 1; then compound 3.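

In this assay, for the compounds shown here, putting methyl in place of trifluoromethyl on an aromatic carbon, meta to a large group, gives an 18-fold higher number from compound 2 to compound 3 (1.26 log units; beyond the scatter) and is the first change here that can be read on its own. Compound 2 and compound 3 differ in this one place only, so this single group accounts for a large loss of potency in this assay, and this position clearly does not tolerate every small group equally. Nothing shown here explains why the swap has so large an effect. 

Going by these compounds alone, with only two groups compared at this position, it remains open whether trifluoromethyl is unusually favourable or methyl unusually poor. A chlorine atom, a methoxy group or an amine at the same place would show where other groups fall relative to these two.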